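Series notes: methyl to methoxy on the aryl group

The source may hold more compounds than are shown below. What is called first, only, known or untested is meant among the compounds shown, and "the series" means these compounds.

The series shares one core, seen in compound 1 `COc1ccccc1-c1cn(C[C@H](O)[C@H]2OC(=O)C(OCc3ccccc3)=C2OCc2ccccc2)nn1`, compound 2 `O=C1O[C@H]([C@@H](O)Cn2cc(CNS(=O)(=O)c3ccc(F)cc3)nn2)C(OCc2ccccc2)=C1OCc1ccccc1` and compound 3 `Cc1ccc(-c2cn(C[C@H](O)[C@H]3OC(=O)C(OCc4ccccc4)=C3OCc3ccccc3)nn2)cc1`, all read in a functional assay on MCF7 cells (Homo sapiens) for antiproliferative activity, read by MTT assay, with a stated time of 72 h; on this read-out lower numbers stand for stronger inhibition and higher numbers for weaker inhibition. In this assay compound 1 reports only a limit, > 100000 nM. Compound 2 gives 26800 nM. Compound 3 likewise reports only a limit, > 100000 nM. Compound 3 thus stands at the limit, together with compound 1 (the limit of > 100000 nM in this assay, at which 2 of the 3 values shown sit), while compound 2 lies lower: an at least 3.7-fold lower number from compound 1 to compound 2 (0.57 log units; beyond the scatter) and an at least 3.7-fold higher number from compound 2 to compound 3 (0.57 log units; beyond the scatter). Between the two aryl variants the step is a step that the two limits leave unreadable from compound 1 to compound 3.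

Compound 4 `COc1ccc(-c2cn(C[C@H](O)[C@H]3OC(=O)C(OCc4ccccc4)=C3OCc3ccccc3)nn2)cc1` differs from compound 3 by methoxy in place of methyl on an aromatic carbon. Among the measured compounds shown here, no measured step exchanges methyl for methoxy on this ring; the nearest comparison, 2-methoxyphenyl against 4-methylphenyl, leaves both compounds at the limit. Both aryl variants measured so far sit at the limit, and only the sulfonamide of compound 2 moves off it, so the expectation for compound 4 is a further value at or near the limit, with a step that the limit leaves unreadable from compound 3 to compound 4 expected to stay small if a number is returned at all. Compound 4 is estimated at 150000 nM, in a range from 40000 nM to 500000 nM.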

Compound 4, half-maximal inhibitory concentration: 99700 nM
Compound 4: middle estimate off by 1.5-fold (0.18 log units), on the high side; the measured number falls inside the stated range.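

Among the compounds shown here, compound 4 is the first of the aryl variants in this assay to return a number instead of a limit, so 4-methoxyphenyl gives a readable value on this aromatic carbon, where 4-methylphenyl and 2-methoxyphenyl did not: a number no higher from compound 3 to compound 4 (the limit leaves the size open) and a number no higher from compound 1 to compound 4 (the limit leaves the size open). Exchanging the (((4-fluorophenyl)sulfonyl)amino)methyl group for 4-methoxyphenyl gives a 3.7-fold higher number from compound 2 to compound 4 (0.57 log units; beyond the scatter), so among the four compounds the sulfonamide of compound 2 still holds the lowest number, and the methoxy group does not close that gap. The steps to compound 4 from compound 3 and from compound 1 cannot be read, because each has a limit at one end: the limit of > 100000 nM in this assay, at which 2 of the 4 values shown sit.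

From the compounds shown here alone, it therefore stays open whether methoxy in place of methyl lowers the number at all, and whether the place of the methoxy on the ring matters, since neither comparison has a size. Also open, going by these compounds, is whether an amine, a carboxylic acid or a longer alkoxy chain in the place of the methoxy would bring the aryl series closer to compound 2.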